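A Methoxy Group Added to a Bromobenzanilide Core

The source may hold more compounds than are shown below. What is called first, only, known or untested is meant among the compounds shown, and "the series" means these compounds.

The series begins with compound 1 `O=C(Nc1ccccc1)c1cccc(Br)c1`, an amide joining two aromatic rings. In an assay for inhibition of HSP60/HSP10 (Homo sapiens), with a stated time of 60 min (a higher number here means a weaker inhibitor, a lower number a stronger inhibitor), compound 1 reaches only a limit of the assay, > 100000 nM. Compound 2 `O=C(Nc1cccc(Cl)c1)c1cccc(Br)c1` is the chloro-bearing analogue, and in this assay compound 2 again gives only a limit, > 100000 nM. Compound 3 `O=C(Nc1cccc(Cl)c1)c1cccc(Br)c1O` additionally carries a hydroxy substituent, and in this assay compound 3 also stops at a limit, > 100000 nM. The two measured steps are therefore unreadable: a step that the two limits leave unreadable from compound 1 to compound 2 and a step that the two limits leave unreadable from compound 2 to compound 3. This is where compound 2 stands: in this assay nothing more than a limit is known for it, and the same holds for the whole set, because of the limit of > 100000 nM in this assay, at which 3 of the 3 values shown sit.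

Compound 4 `COc1ccc(Br)cc1C(=O)Nc1cccc(Cl)c1` differs from compound 2 by methoxy in place of hydrogen on an aromatic carbon. The measured steps bear on this change only as precedents: neither a chloro nor a hydroxy addition moved a compound off the limit, and no step size can be read from them. The step from compound 2 to compound 4 is therefore expected to be a number no higher from compound 2 to compound 4 (the limit leaves the size open), none beyond the scatter. Compound 4 is estimated at 100000 nM, within a range of 30000 nM to 300000 nM.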

Compound 4, half-maximal inhibitory concentration: > 100000 nM
Compound 4 ended at the assay's limit (the forecaster's own chance of this, stated with the estimate: 80%); the middle value lies on the limit itself.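

Going by these compounds alone, compound 2 and compound 4 both stop at a limit in this assay, so the methoxy change between them gives no step whose size can be read. The compounds shown leave open how strongly any of them inhibits, and which change to the shared core, if any, would give a measurable value: the limit of > 100000 nM in this assay, at which 4 of the 4 values shown sit.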